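Exchanging Phenyl for 2,4-Dichlorophenyl on the Amide

The source may hold more compounds than are shown below. What is called first, only, known or untested is meant among the compounds shown, and "the series" means these compounds.

In a functional assay on HUVEC cells (Homo sapiens) for inhibition, tested at 10 ug/mL (a higher number here means a stronger effect of the compound at the concentration tested, a lower number a weaker effect), the measured compounds give:
compound 1 `COc1cc(/C=C/C(=O)c2cccc(N)c2)ccc1O` gives 90%;
compound 2 `COc1cc(/C=C/C(=O)c2cccc(NC(=O)C(C)C)c2)ccc1O` gives 56%;
compound 3 `COc1cc(/C=C/C(=O)c2cccc(NC(=O)c3ccccc3)c2)ccc1O` gives 69%.

Compound 3 stands second highest of the three: the nearer step is a number 13 percentage points higher from compound 2 to compound 3 (beyond the scatter), the further one a number 21 percentage points lower from compound 1 to compound 3 (beyond the scatter). Compound 4 `COc1cc(/C=C/C(=O)c2cccc(NC(=O)c3ccc(Cl)cc3Cl)c2)ccc1O` differs from compound 3 by 2,4-dichlorophenyl in place of phenyl on a carbonyl carbon. Going by the values given here, only one measured step alters this same place, the modest a number 13 percentage points higher from compound 2 to compound 3 (beyond the scatter); the other two, a number 34 percentage points lower from compound 1 to compound 2 (beyond the scatter) and a number 21 percentage points lower from compound 1 to compound 3 (beyond the scatter), replace the hydrogen on the nitrogen instead. Among the compounds with values here, no measured step adds chlorine anywhere, so there is no direct precedent. The expectation is therefore a change that stays within the scatter, a number 3 percentage points lower from compound 3 to compound 4 (within the scatter). Compound 4 is estimated at 66%, with a range from 45% to 85%.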

Compound 4, a percentage reported as inhibition, at one concentration (the size of the read-out at that concentration, not a potency): 70%
Compound 4: the middle estimate sits 4 percentage points below what was measured; low and high end bracket the measured number.
By their numbers in this assay, from the lowest: compound 2; then compounds 3 and 4 (each within the scatter of the next); then compound 1.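

In this assay, 2,4-dichlorophenyl in place of phenyl gives no readable difference: a number 1 percentage points higher from compound 3 to compound 4 (within the scatter). The position on the carbonyl carbon thus accepts the two chlorines, with the separation from the isopropyl amide still standing, a number 14 percentage points higher from compound 2 to compound 4 (beyond the scatter), and the separation from the free amine also remaining, a number 20 percentage points lower from compound 1 to compound 4 (beyond the scatter). No available evidence bears on the reason for this result.

On these data alone, it remains open whether a single chlorine would behave the same way. As far as these compounds go, it is also open whether a carboxylic acid on the phenyl ring, or a longer chain on the carbonyl carbon, would bring the number closer to that of compound 1.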